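Amide substituent replacement from compound 3 to compound 4

This account rests on a few compounds, and the source may have more. Where it says the series, first, only, none or still open, it means among the compounds named here.

Three compounds of the series have numbers in an assay on HEK293 cells for displacement of a labelled ligand from NPC1-like intracellular cholesterol transporter 1 (Homo sapiens); on this read-out lower numbers stand for stronger inhibition and higher numbers for weaker inhibition. Compound 1 `CC(C)(C)OC(=O)NCCCNC(=O)CN1CN(c2ccccc2)C2(CCN(C(=O)c3ccc(C(C)(C)C)cc3)CC2)C1=O` gives 4500 nM. Compound 2 `CC(C)(C)c1ccc(C(=O)N2CCC3(CC2)C(=O)N(CC(=O)N2CCN(S(C)(=O)=O)CC2)CN3c2ccccc2)cc1` gives 19000 nM, and compound 3 `CC(C)(C)c1ccc(C(=O)N2CCC3(CC2)C(=O)N(CC(=O)NCN)CN3c2ccccc2)cc1` gives 26500 nM. Compound 3 sits at the top of the three numbers: a 1.4-fold higher number from compound 2 to compound 3 (0.14 log units; within the scatter) lies within the scatter, whereas a 5.9-fold higher number from compound 1 to compound 3 (0.77 log units; beyond the scatter) lies beyond it.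

Compound 4 `CC(C)(C)c1ccc(C(=O)N2CCC3(CC2)C(=O)N(CC(=O)N2CCCCC2CCO)CN3c2ccccc2)cc1` differs from compound 3 in one place: 2-(2-hydroxyethyl)piperidin-1-yl in place of (aminomethyl)amino on a carbonyl carbon. For the measured compounds named here, two measured steps touch this carbonyl carbon. a 4.2-fold higher number from compound 1 to compound 2 (0.63 log units; beyond the scatter) replaced a chain-type substituent with a cyclic amine, and a 1.4-fold higher number from compound 2 to compound 3 (0.14 log units; within the scatter) exchanged that cyclic amine for the (aminomethyl)amino group without moving beyond the scatter. Compound 4 again carries a cyclic amine on this carbonyl carbon, as compound 2 does, so a number near those of compound 2 and compound 3 is expected rather than a return toward compound 1. The step of a 1.8-fold lower number from compound 3 to compound 4 (0.25 log units; within the scatter) is expected to stay within or close to the scatter, if anything toward a lower number. For compound 4 the estimate in this assay is 15000 nM, with a range from 4000 nM to 50000 nM.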

Compound 4, half-maximal inhibitory concentration: 6100 nM
For compound 4 the middle estimate is 2.5-fold (0.39 log units) above the measured one, and the stated range covers the measured number.
By their numbers in this assay, from the lowest: compounds 1 and 4 (each within the scatter of the next); then compounds 2 and 3 (each within the scatter of the next).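

For the compounds shown here, the step of a 4.3-fold lower number from compound 3 to compound 4 (0.64 log units; beyond the scatter) shows in this assay that a ring-bearing substituent on this carbonyl carbon can also give a lower number, whereas the earlier steps away from compound 1 led only to higher numbers. A cyclic amine alone does not set the number here: the step of a 3.1-fold lower number from compound 2 to compound 4 (0.49 log units; beyond the scatter) separates 2-(2-hydroxyethyl)piperidin-1-yl from 4-(methylsulfonyl)piperazin-1-yl and is printed as beyond the scatter. A simple contrast of chain and ring also fails, as the step of a 1.4-fold higher number from compound 1 to compound 4 (0.13 log units; within the scatter) leaves the (3-((tert-butoxycarbonyl)amino)propyl)amino chain and the 2-(2-hydroxyethyl)piperidin-1-yl ring within the scatter of each other.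

Going by these compounds, it remains open whether the hydroxyl or the piperidine ring carries the step, which a plain piperidin-1-yl group or a 2-ethylpiperidin-1-yl group would help to separate. On these data alone, the role of the side chain also remains open, and could be tested with a longer chain in 2-(3-hydroxypropyl)piperidin-1-yl or an amine in 2-(2-aminoethyl)piperidin-1-yl. No evidence at hand bears on the reason for these steps.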